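This account rests on a few compounds, and the source may have more. Where it says the series, first, only, none or still open, it means among the compounds named here.

Among the measured compounds shown here, compound 2 `Cn1nc(C(F)(F)F)cc1C(=O)Nc1ccc(S(=O)(=O)n2ccc3ccccc32)cc1` is the only compound here with a number in an ADME assay on Vero cells (Chlorocebus sabaeus) for cytotoxicity, read by MTT assay; a lower number here means that less compound is tolerated, a higher number that more compound is tolerated: compound 2 gives 13000 nM. Compound 1 `Cn1nc(C(F)(F)F)cc1C(=O)Nc1ccc(S(=O)(=O)N2CCC[C@H]2C(=O)O)cc1` reaches only a limit in this assay, > 300000 nM. For the measured compounds named here, the single measured step, an at least 23-fold lower number from compound 1 to compound 2 (1.36 log units; beyond the scatter), is large. Compound 3 `Cn1nc(C(F)(F)F)cc1C(=O)Nc1ccc(S(=O)(=O)N2CCCCC2)cc1` differs from compound 2 by piperidin-1-yl in place of 1H-indol-1-yl on a sulfonyl sulfur. The group entering in compound 3 is neither of the two groups compared in that step. Compound 3 is therefore expected to land between the two measured compounds, a step of a 6.2-fold higher number from compound 2 to compound 3 (0.79 log units; beyond the scatter) from compound 2 to compound 3. The estimate for compound 3 is 80000 nM, within 20000 nM to 300000 nM.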

Compound 3, half-maximal cytotoxic concentration: > 300000 nM
Compound 3: no number, only a limit (the forecaster's own chance of this, stated with the estimate: 30%); middle value at least 3.7-fold (0.57 log units) from the limit.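

Piperidin-1-yl in place of 1H-indol-1-yl on the sulfonyl sulfur gives an at least 23-fold higher number from compound 2 to compound 3 (1.36 log units; beyond the scatter) in this assay. A ring with no carboxylic acid therefore also reaches the limit, and among these compounds only compound 2, with 1H-indol-1-yl, gives a number. The step from compound 1 to compound 3 cannot be read, because both values are limits: the limit of > 300000 nM in this assay, at which 2 of the 3 values shown sit.

Still open, as far as these compounds go, is which part of 1H-indol-1-yl goes with the lower number. A pyrrol-1-yl or an open-chain diethylamino group on the sulfonyl sulfur would bear on this.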